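A few compounds are considered here, and "the series" means these few. Any claim that something is new, unique, unknown or untested is made for them only; others in the source may bear on it.

Compound 1 `CCOC(=O)C1=Cc2ccccc2OC1(OCc1cc(-c2ccc(OC)cc2)no1)C(F)(F)F` carries an ethyl ester and a trifluoromethyl group on its shared core, with a 4-methoxyphenyl group hanging from a five-membered heteroaromatic ring. In a functional assay on MCF7 cells (Homo sapiens) for inhibition, read by MTT assay, with a stated time of 24 h (on this read-out higher numbers stand for weaker inhibition and lower numbers for stronger inhibition), compound 1 gives > 150000 nM, which is a limit of the assay rather than a number. Compound 2 `CCOC(=O)C1=Cc2ccccc2OC1(OCc1cn(CC(=O)Nc2cccc(F)c2)nn1)C(F)(F)F` keeps the same core but bears a different side chain ending in an amide. In this assay compound 2 also gives > 150000 nM, again a limit of the assay. Both values sit at the limit of > 150000 nM in this assay, at which 2 of the 2 values shown sit, so the core itself shows no measurable inhibition here. Compound 3 `CCOC(=O)C1=Cc2ccccc2OC1(OCc1cc(-c2ccc(Br)cc2)no1)C(F)(F)F` differs from compound 1 by bromo in place of methoxy on an aromatic carbon. The step that the limit leaves unreadable from compound 1 to compound 3 is expected to fall within the usual scatter, with no gain in inhibition. Compound 3 is therefore estimated at 200000 nM, with a range from 100000 nM to 400000 nM, and a limit rather than a number is likely to be reported.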

Compound 3, half-maximal inhibitory concentration: > 150000 nM
Compound 3 gave a limit, no number; the forecaster's own chance of this, stated with the estimate: 85%; the middle value does not contradict the limit.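

No step can be read from compound 1 to compound 3, bromo in place of methoxy, because both results are limits rather than numbers in this assay: the limit of > 150000 nM in this assay, at which 3 of the 3 values shown sit. The compounds shown leave open which structural change, if any, would give a measurable value in this assay.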